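This account rests on a few compounds, and the source may have more. Where it says the series, first, only, none or still open, it means among the compounds named here.

Working notes on the series. Compound 1 `CC(=O)N1CCC(Sc2c[nH]c3ccc(Cl)cc23)CC1` and compound 2 `CC(=O)N1CCC(Sc2c[nH]c3ccc(Br)cc23)CC1` share one core; in a functional assay on the whole organism with Mus musculus as the target, in the hot plate test (on this read-out higher numbers stand for an effect only at larger amounts of compound and lower numbers for an effect already at smaller amounts), compound 1 gives 3.8 mg/kg, and compound 2 gives 2.8 mg/kg. For the measured compounds named here, their single change, (bromo in place of chloro on an aromatic carbon), made the step of a 1.4-fold lower number from compound 1 to compound 2 (0.13 log units; within the scatter). Compound 3 `Cc1[nH]c2ccc(Cl)cc2c1SC1CCNCC1` is built on a second core; the difference between the two cores is not broken down here. In this assay compound 3 gives 9.9 mg/kg, the highest number of the three, beyond the scatter from compound 1 and compound 2. Compound 4 `Cc1[nH]c2ccc(Br)cc2c1SC1CCNCC1` carries the same change on the core of compound 3, (bromo in place of chloro on an aromatic carbon), at a place described in the same words. The step from compound 3 to compound 4 is expected to be small, a 1.3-fold lower number from compound 3 to compound 4 (0.12 log units; within the scatter), because the matched step a 1.4-fold lower number from compound 1 to compound 2 (0.13 log units; within the scatter) stayed within the scatter. For compound 4 the expected value in this assay is 7.5 mg/kg, with a range from 3.5 mg/kg to 15 mg/kg.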

Compound 4, dose for half-maximal effect: 3.1 mg/kg
The estimate for compound 4 lay 2.4-fold (0.38 log units) above the measured number, and the stated range ends above it.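

In this assay, bromo in place of chloro gives a 3.2-fold lower number from compound 3 to compound 4 (0.50 log units; beyond the scatter), a modest step beyond the scatter. Set beside the matched step on the other core, it cannot be told apart in size: the same change on two cores in this assay, a 1.4-fold lower number (0.13 log units; within the scatter) from compound 1 to compound 2 and a 3.2-fold lower number (0.50 log units; beyond the scatter) from compound 3 to compound 4, 2.4-fold (0.37 log units) apart, within the scatter of two such steps. The change therefore carries between these two cores as far as one pair on each can show, but this does not fix the size of the step or show that it would hold on any further core.

From the compounds shown here alone, whether fluoro, iodo or a nitrile on the same aromatic carbon would fit with these steps remains open. Also open, going by these compounds, is how the difference between the two cores divides among its parts.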